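Solubility notes: from compound 3 to compound 4

The source may report more compounds than this note shows. Statements on the series, on what has been measured and on what is new or still open speak of the compounds shown alone.

Measured in a physicochemical assay for solubility, using the shake flask method, in phosphate buffer, measured as kinetic solubility, with a stated time of 20 h, at pH 6.5; a higher number here means a more soluble compound, a lower number a less soluble compound:
- compound 1 `FC(F)(F)c1ccc(Nc2cc3[nH]c(-c4cccc(C(F)(F)F)c4)nc3cn2)nc1`: < 5000 nM, a limit
- compound 2 `FC(F)(F)c1ccc(Nc2cc3[nH]c(C4CCOC4)nc3cn2)nc1`: 166000 nM
- compound 3 `CC1(c2nc3cnc(Nc4ccc(C(F)(F)F)cn4)cc3[nH]2)CC1`: 188000 nM

Compound 3 stands level with compound 2, with a 1.1-fold higher number from compound 2 to compound 3 (0.05 log units; within the scatter). Compound 1 is reported only as a limit. Compound 4 `FC1(F)CCC(c2nc3cnc(Nc4ccc(C(F)(F)F)cn4)cc3[nH]2)CC1` carries the change (4,4-difluorocyclohexyl in place of 1-methylcyclopropyl on an aromatic carbon). The steps bearing on it are those away from 3-(trifluoromethyl)phenyl: an at least 33-fold higher number from compound 1 to compound 2 (1.52 log units; beyond the scatter) and an at least 37-fold higher number from compound 1 to compound 3 (1.57 log units; beyond the scatter), both large. Compound 4 keeps a non-aromatic ring, as does compound 3 at 188000 nM, so a high number is expected. With no measured case of this group, the expected step is a 3.1-fold lower number from compound 3 to compound 4 (0.50 log units; beyond the scatter), a moderate fall. For compound 4 the estimate in this assay is 60000 nM, with a range of 15000 nM to 180000 nM.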

Compound 4, solubility: 99000 nM
For compound 4 the middle estimate is 1.7-fold (0.22 log units) below the measured one; the measured number falls inside the stated range.
By their numbers in this assay, from the lowest: compounds 4, 2 and 3 (each within the scatter of the next). At a limit, below all of these: compound 1.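

In this assay, 4,4-difluorocyclohexyl on this aromatic carbon between two ring nitrogen atoms stays level with the other two non-aromatic rings: a 1.9-fold lower number from compound 3 to compound 4 (0.28 log units; within the scatter) and a 1.7-fold lower number from compound 2 to compound 4 (0.22 log units; within the scatter). Compound 1 is known only as a limit, < 5000 nM. The large step away from 3-(trifluoromethyl)phenyl therefore holds for a third non-aromatic ring, with an at least 19-fold higher number from compound 1 to compound 4 (1.29 log units; beyond the scatter).

Open, from the compounds shown here alone, is how an amine or a carboxylic acid at this position would read in this assay. A longer chain would test whether a non-aromatic ring is needed here at all.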